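The source may hold more compounds than are shown below. What is called first, only, known or untested is meant among the compounds shown, and "the series" means these compounds.

Compound 1 `COc1ccc(-c2cc(C3=Nc4c(C(C)(C)C)nn(CCCO)c4C(=O)NC3)ccc2OC)c(OC)c1` and compound 2 `COc1ccccc1-c1cc(C2=Nc3c(C(C)(C)C)nn(CCCO)c3C(=O)NC2)ccc1OC` share one core and differ in a single place. In an ADME assay on microsomes from liver (Homo sapiens) for metabolic stability (a higher number here means that the compound lasts longer, a lower number that the compound disappears faster), compound 1 gives 2 h, while compound 2 gives 1.37 h. For the measured compounds named here, the step of a 1.5-fold lower number from compound 1 to compound 2 (0.16 log units; within the scatter) is within the scatter, so the two cannot be told apart; on paper, compound 2 stands at the smaller of the two numbers in this assay, with compound 1 as its only neighbour.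

Compound 3 `COc1ccc(-c2cc(C3=Nc4c(C(C)(C)C)nn(CCCO)c4C(=O)NC3)ccc2OC)cn1` has not yet been measured in this assay. It differs from compound 2 by 6-methoxypyridin-3-yl in place of 2-methoxyphenyl on an aromatic carbon. Going by the values given here, no measured step exchanges one aromatic group for another. Among the compounds with values here, the only measured step, a 1.5-fold lower number from compound 1 to compound 2 (0.16 log units; within the scatter), concerns the very group that is exchanged here, yet it merely removes a methoxy group and stays within the scatter. Nothing measured therefore points to a step beyond the scatter in this assay in either direction, and the expected step is a 1.2-fold higher number from compound 2 to compound 3 (0.07 log units; within the scatter).

For compound 3 the estimated half-life in this assay is 1.6 h, expected to fall between 0.8 h and 3.2 h.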

Compound 3, half-life: 2 h
Compound 3: middle estimate off by 1.3-fold (0.10 log units), on the low side; measured number inside the range.
By their numbers in this assay, from the lowest: compounds 2, 1 and 3 (each within the scatter of the next).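

For the compounds shown here, this is the first measured exchange of one aromatic group for another at this position, where the earlier step only removed a methoxy group. In this assay 6-methoxypyridin-3-yl in place of 2-methoxyphenyl gives a 1.5-fold higher number from compound 2 to compound 3 (0.16 log units; within the scatter) and 6-methoxypyridin-3-yl in place of 2,4-dimethoxyphenyl gives no change at the digits printed from compound 1 to compound 3 (within the scatter) and so, on an aromatic carbon ortho to a methoxy group, a six-membered aromatic ring with one hetero atom cannot be told apart from either ring of carbon only. All three groups at this place lie within the scatter of one another, and no evidence is available to explain the result.

The compounds shown leave open whether 6-methoxypyridin-3-yl would give a comparable half-life without its methoxy group, since every group seen here carries at least one. They also leave open whether an amine or a carboxylic acid on that ring, or a saturated ring such as piperidine in its place, would produce a step beyond the scatter.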